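A few compounds are considered here, and "the series" means these few. Any claim that something is new, unique, unknown or untested is made for them only; others in the source may bear on it.

Among the measured compounds shown here, in a functional assay on U-373MG ATCC cells (Homo sapiens) for inhibition, read by MTT assay, with a stated time of 72 h (on this read-out lower numbers stand for stronger inhibition of growth and higher numbers for weaker inhibition of growth), compound 1 `COC(=O)/C=C/C1=CC[C@H]2C(C)(C)CCC[C@]2(C)[C@H]1C=O` gives 22000 nM and compound 2 `COC(=O)/C=C/C=C/C1=CC[C@H]2C(C)(C)CCC[C@]2(C)[C@H]1C=O` gives 27000 nM, so compound 2 stands within the scatter of its only measured neighbour. Compound 3 `CC1(C)CCC[C@]2(C)[C@@H](C=O)C(/C=C/C#N)=CC[C@@H]12` has cyano in place of 2-(methoxycarbonyl)ethenyl on a double-bonded chain carbon bound to a double-bonded chain carbon. For the measured compounds named here, the only measured step bearing on this change is a 1.2-fold higher number from compound 1 to compound 2 (0.09 log units; within the scatter), which lies within the scatter. Going by the values given here, no cyano compound has been measured, so this is thin evidence, and no step beyond the scatter is expected in this assay. The expected step is a 1.1-fold lower number from compound 2 to compound 3 (0.03 log units; within the scatter). The estimate for compound 3 is 25000 nM, with an expected range of 10000 nM to 60000 nM.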

Compound 3, concentration for 50% growth inhibition: 36000 nM
Compound 3: the middle estimate sits 1.4-fold (0.16 log units) below what was measured; the range from low to high includes it.
By their numbers in this assay, from the lowest: compounds 1, 2 and 3 (each within the scatter of the next).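

In this assay, cyano in place of 2-(methoxycarbonyl)ethenyl gives a 1.3-fold higher number from compound 2 to compound 3 (0.12 log units; within the scatter) and cyano in place of methoxycarbonyl gives a 1.6-fold higher number from compound 1 to compound 3 (0.21 log units; within the scatter) on the same double-bonded chain carbon. The position therefore accepts a nitrile as well as either ester chain, with no step beyond the scatter among the three compounds. Nothing at hand gives a reason for this result. On these data alone, whether a carboxylic acid or an amine at this place would give a step beyond the scatter remains open. So does the effect of a longer chain ending in nitrile.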